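Adding an Isopropyl Group to Compound 1

A few compounds are considered here, and "the series" means these few. Any claim that something is new, unique, unknown or untested is made for them only; others in the source may bear on it.

In a functional assay on PC-3 cells (Homo sapiens) for antiproliferative activity, read by MTT assay, with a stated time of 48 h (a lower number here means a stronger inhibitor, a higher number a weaker inhibitor), compound 1 `O=C(/C=C/c1ccc(/C=C/C(=O)c2ccccc2)o1)NO` gives 13300 nM. This is the lower of the two numbers available, and so the stronger result: compound 2 `O=C(NO)c1ccc(/C=C/c2ccccc2O)o1` gives 91300 nM, a gap beyond the usual scatter. The two structures differ in more than one place, so this pair cannot show the effect of any single change.

The next molecule, compound 3 `CC(C)c1ccc(C(=O)/C=C/c2ccc(/C=C/C(=O)NO)o2)cc1`, keeps the core of compound 1 and makes one change: isopropyl in place of hydrogen on an aromatic carbon. The isopropyl replaces hydrogen on an aromatic carbon, para to a large group. Going by the values given here, no measured pair shows what a group at this place does in this assay, so no clear direction can be expected. The estimated step of a 1.3-fold lower number from compound 1 to compound 3 (0.12 log units; within the scatter) is expected to stay within the usual scatter. Compound 3 is expected at about 10000 nM, with an estimated range from 3500 nM to 28000 nM.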

Compound 3, half-maximal inhibitory concentration: 2270 nM
Compound 3: middle estimate off by 4.4-fold (0.64 log units), on the high side, outside the stated range (below it).
By their numbers in this assay, from the lowest: compound 3; then compound 1; then compound 2.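

Going by these compounds alone, with compound 3, a group at this place has a measured effect for the first time: in this assay, putting isopropyl in place of hydrogen on the six-membered aromatic ring, para to a large group, gives a 5.9-fold lower number from compound 1 to compound 3 (0.77 log units; beyond the scatter), a modest step. This place on the ring therefore accepts a branched group of three carbons without a loss in this assay and even with a gain, which the unmatched pair of compound 1 and compound 2 could not show. Nothing measured here explains why the number falls.

One group at one place does not yet show a trend. As far as these compounds go, it remains open whether a methyl, a longer chain, an amine or a carboxylic acid at this place would lower the number as well, and whether isopropyl would do the same elsewhere on the ring.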